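Chlorine Enters a Flat Fluorophenyl Series

The compounds below may be only part of what the source reports. "The series", "measured", "known", "first", "only" and "open" are said of these compounds alone.

In a functional assay (a higher number here means a weaker inhibitor, a lower number a stronger inhibitor), compound 1 `CC(C)=CCOc1ccc2c(c1)OC(c1ccccc1F)CC2=O` gives 6360 nM and compound 2 `CC(C)=CCOc1ccc2c(c1)OC(c1cccc(F)c1)CC2=O` gives 4280 nM while compound 3 `CC(C)=CCOc1ccc2c(c1)OC(c1ccc(F)cc1)CC2=O` gives 7320 nM and so stands within the scatter of both. Compound 4 `CC(C)=CCOc1ccc2c(c1)OC(c1ccccc1Cl)CC2=O` differs from compound 3 by 2-chlorophenyl in place of 4-fluorophenyl on a saturated ring carbon with 2-chlorophenyl in place of 4-fluorophenyl on a saturated ring carbon. Among the compounds with values here, the steps that bear on it are a 1.2-fold higher number from compound 1 to compound 3 (0.06 log units; within the scatter) and a 1.7-fold higher number from compound 2 to compound 3 (0.23 log units; within the scatter) and also a 1.5-fold lower number from compound 1 to compound 2 (0.17 log units; within the scatter) and none leaves the scatter. Within the data shown here, no measured step replaces fluorine with chlorine. Compound 1 at 6360 nM holds the 2-fluorophenyl, the closest measured match to the entering group. In this assay the expected change is a 1.2-fold lower number from compound 3 to compound 4 (0.09 log units; within the scatter) and no larger than the scatter. Compound 4 is estimated at 6000 nM with an expected range from 2500 nM to 14000 nM in this measurement.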

Compound 4, half-maximal inhibitory concentration: 8020 nM
Compound 4: middle estimate off by 1.3-fold (0.13 log units), on the low side; measured number inside the range.
By their numbers in this assay, from the lowest: compounds 2, 1, 3 and 4 (each within the scatter of the next).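

In this assay, within the data shown here, the chloro in place of fluoro on an aromatic carbon gives a 1.3-fold higher number from compound 1 to compound 4 (0.10 log units; within the scatter) and is the one exchange of halogen itself at this position, so this change does not separate the two compounds. The other steps, a 1.1-fold higher number from compound 3 to compound 4 (0.04 log units; within the scatter) and a 1.9-fold higher number from compound 2 to compound 4 (0.27 log units; within the scatter) also stay inside the scatter, which extends the flat picture from fluorophenyl to 2-chlorophenyl on this saturated ring carbon. Nothing measured here accounts for this flatness. The compounds shown leave open whether the picture holds beyond halogens, for instance with an amine or a carboxylic acid on the phenyl ring.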